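This account rests on a few compounds, and the source may have more. Where it says the series, first, only, none or still open, it means among the compounds named here.

In a toxicity assay on MT4 cells (Homo sapiens) for cytotoxicity, read by MTT assay (on this read-out higher numbers stand for lower toxicity in this test and lower numbers for higher toxicity in this test), three compounds that share one core have been measured so far. Compound 1 `Cc1cc(-c2ccccc2Cl)cc(C)c1Oc1cc(N)nc(Nc2ccc(C#N)cc2)n1` gives 25100 nM, compound 2 `Cc1cc(-c2ccccc2C#N)cc(C)c1Oc1cc(N)nc(Nc2ccc(C#N)cc2)n1` gives 25400 nM, and compound 3 `Cc1cc(-c2cccc(C#N)c2)cc(C)c1Oc1cc(N)nc(Nc2ccc(C#N)cc2)n1` gives 20200 nM. These numbers all lie within the usual scatter of repeated measurements, so compound 3 cannot be ranked against the other two.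

Compound 4 `Cc1cc(-c2ccc(C#N)c(F)c2)cc(C)c1Oc1cc(N)nc(Nc2ccc(C#N)cc2)n1` has not yet been measured. It differs from compound 3 in one place: 4-cyano-3-fluorophenyl in place of 3-cyanophenyl on an aromatic carbon. In words, 4-cyano-3-fluorophenyl stands in place of 3-cyanophenyl on an aromatic carbon.

The three measured steps all alter the group at this same place, so they are the closest evidence. They are a 1.0-fold higher number from compound 1 to compound 2 (0.01 log units; within the scatter), a 1.2-fold lower number from compound 1 to compound 3 (0.09 log units; within the scatter) and a 1.3-fold lower number from compound 2 to compound 3 (0.10 log units; within the scatter). All three are small and stay within the scatter. None of them adds a fluorine, however, so the data hold no direct test of this particular change. With that caveat, no step beyond the scatter is expected in this assay, in either direction. The estimated change is a 1.0-fold higher number from compound 3 to compound 4 (0.02 log units; within the scatter), which is no real shift. Compound 4 is expected near 21000 nM, with an estimated range from 10000 nM to 40000 nM.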

Compound 4, half-maximal cytotoxic concentration: 5000 nM
Estimate against measurement, compound 4: 4.2-fold (0.62 log units) above, outside the stated range (below it).
By their numbers in this assay, from the lowest: compound 4; then compounds 3, 1 and 2 (each within the scatter of the next).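

In this assay, the group on this aromatic carbon turns out to matter: 4-cyano-3-fluorophenyl gives a 4.0-fold lower number from compound 3 to compound 4 (0.61 log units; beyond the scatter), and the other two comparisons agree, with a 5.1-fold lower number from compound 2 to compound 4 (0.71 log units; beyond the scatter) and a 5.0-fold lower number from compound 1 to compound 4 (0.70 log units; beyond the scatter) as well. The earlier changes, cyano for chloro and a shift from 2-cyanophenyl to 3-cyanophenyl, all stayed within the scatter, so this place looked insensitive, whereas this new group moves the number beyond the scatter, towards higher toxicity in this test. Nothing available here explains why the added fluorine and the changed nitrile place go with this shift.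

Compared with compound 3, compound 4 carries both a new fluorine and its nitrile at a different place on the ring, so the shown compounds cannot say which of the two changes matters, or whether it takes both together. A plain 4-cyanophenyl and a 3-fluorophenyl would separate the two, while a 4-aminophenyl or a 4-carboxyphenyl would show how the number responds to quite different groups at this place.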